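Stereochemistry at the peroxide ring in a diterpenoid series

The source may report more compounds than this note shows. Statements on the series, on what has been measured and on what is new or still open speak of the compounds shown alone.

The account concerns two measured compounds and one awaiting measurement. Compound 1 `C=C1CCCC(C)(C)C1CC[C@]1(C)CC[C@@H]([C@@H](C)C(=O)O)OO1` carries an open carbocycle, and in a functional assay on HOP-92 cells (Homo sapiens) for inhibition (a lower number here means a stronger inhibitor of growth, a higher number a weaker inhibitor of growth), compound 1 gives 6630 nM. Compound 2 `C=C1CCC[C@H]2[C@](C)(CC[C@]3(C)CC[C@@H]([C@@H](C)C(=O)O)OO3)[C@@H](C)CC[C@]12C` holds a fused tricyclic core, and in this assay compound 2 gives 1080 nM, the lowest of the two numbers, with compound 1 standing at a higher number beyond the scatter. Compound 3 `C=C1CCC[C@H]2[C@](C)(CC[C@]3(C)CC[C@H]([C@@H](C)C(=O)O)OO3)[C@@H](C)CC[C@]12C` differs from compound 2 as follows: the two compounds have the same atoms and bonds and differ only in configuration as drawn: 1 of 7 stereo elements differ; a stereocentre at a saturated ring carbon is drawn S in compound 2 and R in compound 3. For the measured compounds named here, the data give no comparable step between measured compounds, so the effect of inverting this ring carbon cannot be read from them. Because compound 2 gives 1080 nM and the change leaves every atom and bond in place, the step is expected to be small, probably within the scatter, with some risk of weakening. Compound 3 is expected to give an estimate of 2000 nM, between 700 nM and 6000 nM, an expected step of a 1.9-fold higher number from compound 2 to compound 3 (0.27 log units; within the scatter).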

Compound 3, concentration for 50% growth inhibition: 290 nM
Compound 3: middle estimate off by 6.9-fold (0.84 log units), on the high side; measured number below the stated range.
By their numbers in this assay, from the lowest: compound 3; then compound 2; then compound 1.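

In this assay, inverting this saturated ring carbon from S to R gives a 3.7-fold lower number from compound 2 to compound 3 (0.57 log units; beyond the scatter), so the configuration at this one position counts on its own, with no atom or bond changed. The earlier compounds shown here could not show this: compound 1 and compound 2 differ in more than one place, and their numbers say nothing about a single ring carbon. The step can be assigned to the inversion alone because nothing else separates the pair: the fact that compounds 2 and 3 differ only in the configuration as drawn.

On these data alone, it remains open whether the same inversion would matter in the open carbocycle of compound 1, and whether inverting any of the other stereo elements would shift the number as well. Also open, as far as these compounds go, is whether the step would hold if a methyl ester or an amide stood in place of the carboxylic acid.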